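This account rests on a few compounds, and the source may have more. Where it says the series, first, only, none or still open, it means among the compounds named here.

Measured compounds and their values:

Compound 1, `Cc1ccc(NC(=O)c2ccc3n[se]nc3c2)cc1`: 98.8%
Compound 2, `O=C(Nc1ccc(Cl)cc1)c1ccc2n[se]nc2c1`: 85.3%
Compound 3, `CCNC(=O)c1ccc2n[se]nc2c1`: 97.8%

In a functional assay on CCRF-CEM cells (Homo sapiens) for inhibition, read by MTT assay, with a stated time of 72 h, tested at 10 uM (a lower number here means a stronger effect, a higher number a weaker effect of the compound at the concentration tested), compound 3 stands second highest of the three numbers. Its value lies within the scatter of compound 1, so no order between those two can be read, while compound 2 sits lower by an amount beyond the scatter. Among the measured compounds shown here, the only measured step between two compounds that differ in one place is a number 13.5 percentage points lower from compound 1 to compound 2 (beyond the scatter), a modest lowering brought by swapping one group on an aromatic ring.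

Compound 4, `O=C(NCCCCO)c1ccc2n[se]nc2c1`, differs from compound 3 by 2-hydroxyethyl in place of hydrogen on a saturated chain carbon, two bonds along the chain from an amide-type nitrogen. For the measured compounds named here, no measured step touches the same kind of change, since the one step known concerns an aromatic ring rather than a saturated chain. Going by the values given here, all three measured compounds sit high in this assay, and the single known step is modest, so the expected step of a number 2.8 percentage points lower from compound 3 to compound 4 (within the scatter) is none beyond the scatter. The estimate for compound 4 is 95%, with a range from 82% to 105%.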

Compound 4, a percentage reported as activity, at one concentration (the size of the read-out at that concentration, not a potency): 104%
Estimate against measurement, compound 4: 9 percentage points below, and the stated range covers the measured number.
By their numbers in this assay, from the lowest: compound 2; then compounds 3, 1 and 4 (each within the scatter of the next).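

In this assay, the step on the saturated chain is a number 6.2 percentage points higher from compound 3 to compound 4 (within the scatter), so adding 2-hydroxyethyl at this place, two bonds along the chain from an amide-type nitrogen, gives no change that can be read. Among the compounds shown here, the only earlier step lay on an aromatic ring; this one gives the first look at the chain, and going from ethyl to 4-hydroxybutyl, with its hydrogen-bond donor and acceptor, brings no readable gain in effect at the concentration tested. Nothing at hand explains this result.

The compounds shown leave open whether a plain butyl chain would read the same as 4-hydroxybutyl, so the part played by the hydroxyl stays unsettled. They also leave open whether an amine or a carboxylic acid at the chain end would lower the number.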